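Second Fluorine on a Series That Sits at the Limit

A few compounds are considered here, and "the series" means these few. Any claim that something is new, unique, unknown or untested is made for them only; others in the source may bear on it.

The three measured compounds share one core and differ only in the substituent on the aryl ketone. Compound 1 `COc1cc(-c2nnc(SCC(=O)c3ccc(Br)cc3)n2N)cc(OC)c1OC` carries bromo there. In a functional assay on PC-3 cells (Homo sapiens) for antiproliferative activity, read by MTT assay, with a stated time of 48 h (on this read-out lower numbers stand for stronger inhibition and higher numbers for weaker inhibition), compound 1 gives > 100000 nM, which is a limit of the assay rather than a number. Compound 2 `COc1cc(-c2nnc(SCC(=O)c3ccc(C(F)(F)F)cc3)n2N)cc(OC)c1OC` carries trifluoromethyl instead; in this assay compound 2 gives > 100000 nM, again a limit. Compound 3 `COc1cc(-c2nnc(SCC(=O)c3ccc(F)cc3)n2N)cc(OC)c1OC` carries fluoro; in this assay compound 3 gives > 100000 nM, also a limit. Going by the values given here, compound 3 thus stands where every value so far stands, at the limit of > 100000 nM in this assay, at which 3 of the 3 values shown sit. The steps between these compounds, a step that the two limits leave unreadable from compound 1 to compound 2, a step that the two limits leave unreadable from compound 1 to compound 3 and a step that the two limits leave unreadable from compound 2 to compound 3, cannot be read, since both ends of each are limits.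

Compound 4 `COc1cc(-c2nnc(SCC(=O)c3ccc(F)c(F)c3)n2N)cc(OC)c1OC` differs from compound 3 by fluoro in place of hydrogen on an aromatic carbon. The three measured steps all concern changes on the same aryl ring, and none of them shows a readable size, so they give no direction for this change in this assay. The step from compound 3 to compound 4 is therefore expected to be a number no higher from compound 3 to compound 4 (the limit leaves the size open). Compound 4 is expected to give about 100000 nM in this assay, within a range from 30000 nM to 300000 nM, and most probably to be reported only as a limit again.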

Compound 4, half-maximal inhibitory concentration: > 100000 nM
Compound 4: a limit, no number (the forecaster's own chance of this, stated with the estimate: 85%); the middle value lies on the limit itself.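

In this assay compound 4 gives > 100000 nM, a limit of the assay and not a number. The steps joining compound 4 to compound 1, compound 2 and compound 3 therefore cannot be read, since both ends of each are limits. The compounds shown leave open whether any substituent on the aryl ketone changes the read-out, as all values share one position: the limit of > 100000 nM in this assay, at which 4 of the 4 values shown sit.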